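The source may report more compounds than this note shows. Statements on the series, on what has been measured and on what is new or still open speak of the compounds shown alone.

Compound 1 `CCC(CC)O[C@@H]1C=C(S(=O)(=O)O)C[C@H](N)[C@H]1NC(C)=O` and compound 2 `CCC(CC)O[C@@H]1C=C(S(=O)(=O)O)C[C@H](NC(=N)N)[C@H]1NC(C)=O` share a core; the difference between them is a group of 3 heavy atoms (1 carbon, 2 nitrogen; no ring) in place of a hydrogen atom, on an amine nitrogen. In an ADME assay on MDCK cells (Canis lupus familiaris) for cytotoxicity, with a stated time of 48 h (on this read-out lower numbers stand for higher toxicity in this test and higher numbers for lower toxicity in this test), compound 1 gives only a limit of the assay, > 100000 nM. Compound 2 likewise gives only a limit in this assay, > 100000 nM. The step that the two limits leave unreadable from compound 1 to compound 2 therefore cannot be sized. Compound 3 `CCC(CC)O[C@@H]1C=C(S(=O)(=O)OCCCc2ccccc2)C[C@H](N)[C@H]1NC(C)=O` differs from compound 1 by 3-phenylpropyl in place of hydrogen on an oxygen, and for compound 3 this assay reports "not determined" (no result reported). Compound 4 `CCC(CC)O[C@@H]1C=C(S(=O)(=O)OCCCc2ccccc2)C[C@H](NC(=N)N)[C@H]1NC(C)=O` differs from compound 3 by a group of 3 heavy atoms (1 carbon, 2 nitrogen; no ring) in place of a hydrogen atom, on an amine nitrogen, the same change as that from compound 1 to compound 2, at the same place. Since both measured values sit at the limit of > 100000 nM in this assay, at which 2 of the 3 values shown sit, the step from compound 3 to compound 4 in this assay is expected to be unreadable in the same way, with compound 4 expected at 100000 nM, between 30000 nM and 300000 nM.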

Compound 4, half-maximal cytotoxic concentration: > 100000 nM
Compound 4: a limit, no number; the forecaster's own chance of this, stated with the estimate: 70%; the middle value lies on the limit itself.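

No new step can be read: compound 2 and compound 4 both give only a limit, and compound 3 has no result. The compounds shown leave open whether 3-phenylpropyl on the oxygen changes the read-out in this assay at all.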